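One more chain carbon on compound 3

This account rests on a few compounds, and the source may have more. Where it says the series, first, only, none or still open, it means among the compounds named here.

In a physicochemical assay for solubility, at pH 7.4 (on this read-out lower numbers stand for lower solubility and higher numbers for higher solubility), compound 1 (`CC(C)OCc1nc(Nc2ccc(C(F)(F)F)cc2)c2ccc(-c3ncccc3C(F)(F)F)cc2n1`) gives 0.04 ug/mL, compound 2 (`O=C(O)COCc1nc(Nc2ccc(C(F)(F)F)cc2)c2ccc(-c3ncccc3C(F)(F)F)cc2n1`) gives 125 ug/mL and compound 3 (`OCCc1nc(Nc2ccc(C(F)(F)F)cc2)c2ccc(-c3ncccc3C(F)(F)F)cc2n1`) gives 0.02 ug/mL. Compound 3 stands level with compound 1, the step between them being a 2.0-fold lower number from compound 1 to compound 3 (0.30 log units; within the scatter). Both lie far under compound 2, and the gap on the side of compound 3 is a 6300-fold lower number from compound 2 to compound 3 (3.80 log units; beyond the scatter).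

Compound 4 (`OCCCc1nc(Nc2ccc(C(F)(F)F)cc2)c2ccc(-c3ncccc3C(F)(F)F)cc2n1`) differs from compound 3 only in its chain: hydroxymethyl in place of hydroxy on a saturated chain carbon, two bonds along the chain from an aromatic carbon. This is hydroxymethyl in place of hydroxy on a saturated chain carbon, two bonds along the chain from an aromatic carbon, and it can also be read as 2-hydroxyethyl to 3-hydroxypropyl. Neither side of the change carries a net charge.

Among the compounds with values here, the two large steps both involve compound 2, the only compound with a carboxymethyl group: a 3100-fold higher number from compound 1 to compound 2 (3.49 log units; beyond the scatter) and a 6300-fold lower number from compound 2 to compound 3 (3.80 log units; beyond the scatter). Compound 4 has no such group, so these steps offer little guidance on size. The closer precedent is the change between two uncharged chains, a 2.0-fold lower number from compound 1 to compound 3 (0.30 log units; within the scatter), which stays within the scatter. Within the data shown here, no chain-length pair has been measured yet, so this remains an inference. No step beyond the scatter is expected, in either direction, and the expected step is no change at the digits printed from compound 3 to compound 4 (within the scatter).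

Compound 4 is estimated at 0.02 ug/mL, with an expected range of 0.006 ug/mL to 0.08 ug/mL.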

Compound 4, solubility: 0.06 ug/mL
Estimate against measurement, compound 4: 3.0-fold (0.48 log units) below, and the stated range covers the measured number.
By their numbers in this assay, from the lowest: compounds 3, 1 and 4 (each within the scatter of the next, the first and the last beyond it); then compound 2.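

In this assay, within the data shown here, the change from 2-hydroxyethyl to 3-hydroxypropyl provides the first chain-length pair, and a 3.0-fold higher number from compound 3 to compound 4 (0.48 log units; beyond the scatter) shows that this position does not stay flat when hydroxymethyl replaces hydroxy, although the step is only modest. Among these compounds, two further steps set its size in context: a 1.5-fold higher number from compound 1 to compound 4 (0.18 log units; within the scatter) leaves these two compounds level, while a 2100-fold lower number from compound 2 to compound 4 (3.32 log units; beyond the scatter) shows that the longer hydroxy chain leaves the large gap to the only compound with a carboxymethyl group in place. Nothing measured on hand accounts for the step seen with the added chain carbon.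

Among the compounds shown here, with only one chain-length step, it remains open whether a longer chain such as 4-hydroxybutyl would continue the upward movement, level off or reverse it. Also open, on these data alone, is how an amine in place of the hydroxy group would read on this scale, and whether a carboxylic acid on an all-carbon chain would reach the level of compound 2 or fall short of it.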